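A few compounds are considered here, and "the series" means these few. Any claim that something is new, unique, unknown or untested is made for them only; others in the source may bear on it.

Measured in a functional assay on CEM13 cells (Homo sapiens) for cytotoxicity, read by MTT assay, with a stated time of 72 h; a higher number here means a weaker inhibitor, a lower number a stronger inhibitor:
- Compound 1 `Cc1c(C)c2c(c(C)c1OC(=O)CCC(=O)O)CCC(C)(C(=O)NCC1CC(C)(C)N([O])C1(C)C)O2`: > 300000 nM (a limit)
- Compound 2 `Cc1c(C)c2c(c(C)c1OC(=O)CCC(=O)O)CCC(C)(C(=O)O)O2`: 191000 nM
- Compound 3 `Cc1c(C)c2c(c(C)c1O)CCC(C)(C(=O)NC1CC(C)(C)N([O])C1(C)C)O2`: > 300000 nM (a limit)

Compound 3 has no number in this assay, only the limit > 300000 nM. This is the limit of > 300000 nM in this assay, at which 2 of the 3 values shown sit.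

Compound 4 `Cc1c(C)c2c(c(C)c1OC(=O)CCC(=O)O)CCC(C)(C(=O)NC1CC(C)(C)N([O])C1(C)C)O2` keeps the amide of compound 3 and carries (2-carboxyethyl)carbonyl in place of hydrogen on an oxygen on an aromatic ring, so that hydroxy becomes ((2-carboxyethyl)carbonyl)oxy: (2-carboxyethyl)carbonyl in place of hydrogen on an oxygen on an aromatic ring.

Going by the values given here, no measured step makes this change directly. Among the compounds with values here, the one step available, an at least 1.5-fold lower number from compound 1 to compound 2 (0.19 log units; that floor lies within the scatter), lies at another place, on a carbonyl carbon, so it bears on the question only indirectly. More can be read from the compounds that already hold the entering group. Compound 1 carries it and still gives > 300000 nM, which is a limit. Compound 2 also carries it and gives 191000 nM.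

Neither compound suggests that the group brings a large drop in the number, so no step beyond the scatter is expected in this assay, in either direction. The expected step is a number no higher from compound 3 to compound 4 (the limit leaves the size open). For compound 4 the estimated value is 300000 nM, with an expected range from 150000 nM to 600000 nM, and the assay may well report only a limit.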

Compound 4, half-maximal inhibitory concentration: 205000 nM
Compound 4: the middle estimate sits 1.5-fold (0.17 log units) above what was measured; measured number inside the range.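

In this assay, changing hydroxy to ((2-carboxyethyl)carbonyl)oxy on the aromatic ring moves the amide series from a limit to a measured number, and the change reads as an at least 1.4-fold lower number from compound 3 to compound 4 (0.16 log units; that floor lies within the scatter). Only that floor can be read, because compound 3 stands at a limit, which is one of two such values here: the limit of > 300000 nM in this assay, at which 2 of the 4 values shown sit. With the ((2-carboxyethyl)carbonyl)oxy group in place, replacing the free acid with the amide gives a 1.1-fold higher number from compound 2 to compound 4 (0.03 log units; within the scatter), so these two values cannot be told apart, while the change on the amide-type nitrogen gives an at least 1.4-fold lower number from compound 1 to compound 4 (0.16 log units; that floor lies within the scatter), which again offers only a floor.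

How large the effect of the group on compound 3 really is stays open, since the compounds shown give no number for the hydroxy amide. From the compounds shown here alone, what a plain acetyl group, a longer chain ending in a carboxylic acid, or a chain ending in an amine would do on that same oxygen also remains open.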